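This account rests on a few compounds, and the source may have more. Where it says the series, first, only, none or still open, it means among the compounds named here.

Among the compounds with values here, compound 2, `CCOC(=O)/C=C(C)/C=C/CC(C)CCC(O)C(C)C`, is the lower of the two measured members. Within the data shown here, in a physicochemical assay for lipophilicity (a higher number here means a more lipophilic compound, a lower number a more polar compound), compound 2 gives 4.65, whereas compound 1, `CCOC(=O)/C=C(C)/C=C/CC(C)CCCC(C)(C)OCC`, gives 6.08; the only recorded step, a number 1.43 log units lower from compound 1 to compound 2 (beyond the scatter), separates them. Compound 3, `CCOC(=O)/C=C(C)/C=C/CC(C)CCC1OC1(C)C`, has not yet been measured. Compound 3 differs from compound 2 by 3,3-dimethyloxiran-2-yl in place of 1-hydroxy-2-methylpropyl on a saturated chain carbon, four bonds along the chain from a double-bonded chain carbon. Among the measured compounds shown here, the one measured step bears on this change only in part: it exchanged the hydroxyl-bearing group for an ethoxy-bearing one and was large, while here a donor-bearing group gives way to a three-membered ring with one oxygen and no donor, a smaller shift in the same direction. A rise beyond the scatter is therefore expected, though well short of the measured step. Compound 3 is estimated at 5.5, between 5 and 6, an expected step of a number 0.85 log units higher from compound 2 to compound 3 (beyond the scatter).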

Compound 3, partition coefficient: 4.76
Beside the measured number, compound 3's estimate is 0.74 log units above it; measured number below the stated range.
By their numbers in this assay, from the lowest: compounds 2 and 3 (each within the scatter of the next); then compound 1.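

In this assay, 3,3-dimethyloxiran-2-yl in place of 1-hydroxy-2-methylpropyl on a saturated chain carbon, four bonds along the chain from a double-bonded chain carbon, gives a number 0.11 log units higher from compound 2 to compound 3 (within the scatter); at this position, a change from 1 hydrogen-bond donor to 0 hydrogen-bond donors, with 5 heavy atoms in both groups, does not by itself separate the two numbers. The same ring in place of 2-ethoxy-2-methylpropyl gives a number 1.32 log units lower from compound 1 to compound 3 (beyond the scatter), so among these three groups only 2-ethoxy-2-methylpropyl sets its compound apart. Nothing at hand accounts for these numbers.

Still open, going by these compounds, is where an amine or a carboxylic acid at this place would stand in this assay. Also open, on these data alone, is whether a longer chain on the ether oxygen would carry the number further from that of compound 1.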